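The source may hold more compounds than are shown below. What is called first, only, known or untested is meant among the compounds shown, and "the series" means these compounds.

In a physicochemical assay for solubility, measured as kinetic solubility, at pH 7.4 (on this read-out lower numbers stand for lower solubility and higher numbers for higher solubility), compound 1 `COc1cc(N2CCC(CC(=O)N3CCOCC3)CC2)ccc1Nc1nc(NC2CCCCC2)c2nc[nH]c2n1` gives 19000 nM and compound 2 `COc1cc(N2CCC(CC(=O)N3CCN(C)CC3)CC2)ccc1Nc1nc(NC2CCCCC2)c2nc[nH]c2n1` gives 38000 nM, so the two lie within the scatter of each other. Compound 3 `COc1cc(N2CCC(C(=O)N3CC(O)C3)CC2)ccc1Nc1nc(NC2CCCCC2)c2nc[nH]c2n1` differs from compound 2 as follows: (3-hydroxyazetidin-1-yl)carbonyl in place of ((4-methylpiperazin-1-yl)carbonyl)methyl on a saturated ring carbon. Within the data shown here, the one measured step nearby is a 2.0-fold higher number from compound 1 to compound 2 (0.30 log units; within the scatter), and it changes only the group on the carbonyl carbon. Among the measured compounds shown here, no measured step tests (3-hydroxyazetidin-1-yl)carbonyl, so no shift beyond the scatter is expected in this assay. The expected step is a 1.5-fold lower number from compound 2 to compound 3 (0.18 log units; within the scatter). Compound 3 is estimated at 25000 nM, with an expected range of 8000 nM to 80000 nM.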

Compound 3, solubility: 19000 nM
The estimate for compound 3 lay 1.3-fold (0.12 log units) above the measured number; the measured number falls inside the stated range.
By their numbers in this assay, from the lowest: compounds 1, 3 and 2 (each within the scatter of the next).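

In this assay, the new group on the saturated ring carbon gives a 2.0-fold lower number from compound 2 to compound 3 (0.30 log units; within the scatter) and no change at the digits printed from compound 1 to compound 3 (within the scatter). Replacing either six-membered ring on the longer group with the four-membered ring, which brings a hydrogen-bond donor, therefore produced no step beyond the scatter at this place. Nothing available accounts for this result.

On these data alone, whether a carboxylic acid or a primary amine at this place would move the number beyond the scatter remains open. The shorter link and the new ring also change together here, so their separate contributions cannot be told apart.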